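Swapping the bromophenyl anilide for a chloro-methylphenyl

A few compounds are considered here, and "the series" means these few. Any claim that something is new, unique, unknown or untested is made for them only; others in the source may bear on it.

Compound 2 `O=C(CN1CCN(c2nnc(Cc3ccncc3)c3ccccc23)CC1)Nc1ccc(Br)cc1` gives 1990 nM in a functional assay on HT-29 cells (Homo sapiens) for cytotoxicity, read by MTT assay, with a stated time of 72 h (on this read-out lower numbers stand for stronger inhibition and higher numbers for weaker inhibition), the lowest of the three numbers recorded. Compound 1 `O=C(CN1CCN(c2nnc(Cc3ccccc3)c3ccccc23)CC1)Nc1c(F)cccc1F` gives 19700 nM and compound 3 `O=C(CN1CCN(c2nnc(Cc3ccccc3)c3ccccc23)CC1)Nc1ccc(Br)cc1` gives 60200 nM, so compound 2 is the most potent of the measured set in this assay. Compound 4 `Cc1cccc(Cl)c1NC(=O)CN1CCN(c2nnc(Cc3ccncc3)c3ccccc23)CC1` keeps the pyridin-4-yl side of compound 2 and changes only the amide end: 2-chloro-6-methylphenyl in place of 4-bromophenyl on an amide-type nitrogen.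

Of the measured steps, only a 3.1-fold higher number from compound 1 to compound 3 (0.49 log units; beyond the scatter) touches the same amide-type nitrogen; it shows that trading a 2,6-difluorophenyl for the 4-bromophenyl that now leaves raised the number modestly. The other step, a 30-fold higher number from compound 2 to compound 3 (1.48 log units; beyond the scatter), concerns a different part of the molecule and gives no guidance here. Taking the amide-end step in reverse as the nearest precedent, a modest move toward a lower number in this assay is expected for compound 4, with real uncertainty because the entering group is not the one measured. Compound 4 is therefore estimated at 900 nM, between 300 nM and 3000 nM, a step of a 2.2-fold lower number from compound 2 to compound 4 (0.34 log units; beyond the scatter) that is expected to stay small.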

Compound 4, half-maximal inhibitory concentration: 22600 nM
Compound 4: middle estimate off by 25-fold (1.40 log units), on the low side, and the stated range ends below it.
By their numbers in this assay, from the lowest: compound 2; then compounds 1 and 4 (each within the scatter of the next); then compound 3.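

On the pyridin-4-yl side, this assay shows that the group on the amide-type nitrogen can shift the number strongly: an 11-fold higher number from compound 2 to compound 4 (1.06 log units; beyond the scatter). Going by these compounds alone, the only earlier step at this nitrogen, a 3.1-fold higher number from compound 1 to compound 3 (0.49 log units; beyond the scatter), came from the phenyl side and favoured 2,6-difluorophenyl over 4-bromophenyl, whereas here 4-bromophenyl gives the lower number against a different entering group, so that earlier step did not carry over to this change. Nothing available accounts for the size or direction of the new step.

The compounds shown leave open whether 2,6-difluorophenyl would also give a lower number than 4-bromophenyl on the pyridin-4-yl side. They also leave open how a cyclohexyl on the amide-type nitrogen, with no aromatic ring at that end, would read against 4-bromophenyl.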